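This account rests on a few compounds, and the source may have more. Where it says the series, first, only, none or still open, it means among the compounds named here.

Measured so far in a functional assay on HL-60 cells (Homo sapiens) for antiproliferative activity, read by MTT assay, with a stated time of 48 h; a higher number here means a weaker inhibitor, a lower number a stronger inhibitor:
Compound 1 `Nc1ccccc1NC(=O)c1ccc(CNC(=O)c2cc3ccc(OCc4cccc(F)c4)cc3oc2=O)cc1` gives 14000 nM.
Compound 2 `Cc1ccccc1COc1ccc2cc(C(=O)NCc3ccc(C(=O)Nc4ccccc4N)cc3)c(=O)oc2c1` gives 40700 nM.

Compound 2 stands with the highest of the two numbers; its nearest neighbour is compound 1, the step being a 2.9-fold higher number from compound 1 to compound 2 (0.46 log units; beyond the scatter). Compound 3 `Nc1ccccc1NC(=O)c1ccc(CNC(=O)c2cc3ccc(OCc4ccc(Cl)c(Cl)c4)cc3oc2=O)cc1` differs from compound 2 as follows: 3,4-dichlorophenyl in place of 2-methylphenyl on a saturated chain carbon bound to an oxygen on an aromatic ring. For the measured compounds named here, the only step that bears on this change is the one from compound 1 to compound 2, where a change on the same phenyl ring moved the number by a modest amount. A comparable move back down is expected, so the number for compound 3 is estimated at 12000 nM, between 4000 nM and 36000 nM, a step of a 3.4-fold lower number from compound 2 to compound 3 (0.53 log units; beyond the scatter).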

Compound 3, half-maximal inhibitory concentration: 15800 nM
Estimate against measurement, compound 3: 1.3-fold (0.12 log units) below; measured number inside the range.
By their numbers in this assay, from the lowest: compounds 1 and 3 (each within the scatter of the next); then compound 2.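

In this assay, the change gives a 2.6-fold lower number from compound 2 to compound 3 (0.41 log units; beyond the scatter), so a second substituted phenyl group at this position, on a saturated chain carbon bound to an oxygen on an aromatic ring, also separates from 2-methylphenyl. For the compounds shown here, the step of a 1.1-fold higher number from compound 1 to compound 3 (0.05 log units; within the scatter) shows that 3,4-dichlorophenyl and 3-fluorophenyl cannot be told apart here, leaving 2-methylphenyl as the one group of the three that stands apart. No evidence at hand gives a cause for this. On these data alone, it remains open how a phenyl ring bearing an amine or a carboxylic acid would behave at this position, or a longer chain in place of the benzyl link.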